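Amide swap at piperazine: tert-butyl replaces tert-butoxymethyl

The compounds below may be only part of what the source reports. "The series", "measured", "known", "first", "only" and "open" are said of these compounds alone.

Measured so far:
Compound 1, `O=C(c1ccc(OCCCN2CCN(C(=O)[C@H]3CCCN3)CC2)cc1)C1CC1`, 53700 nM
Compound 2, `CC(C)(C)OC[C@@H](N)C(=O)N1CCN(CCCOc2ccc(C(=O)C3CC3)cc2)CC1`, 45700 nM

Both compounds were tested in an assay for binding affinity to histamine H2 receptor (Homo sapiens); on this read-out lower numbers stand for stronger inhibition and higher numbers for weaker inhibition. Compound 2 gives the lowest of the two numbers, but the gap to compound 1 is small: a 1.2-fold lower number from compound 1 to compound 2 (0.07 log units; within the scatter). On this evidence compound 1 and compound 2 cannot be told apart.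

Compound 3, `CC(C)(C)[C@@H](N)C(=O)N1CCN(CCCOc2ccc(C(=O)C3CC3)cc2)CC1`, differs from compound 2 at the amide side chain: tert-butyl in place of (tert-butoxy)methyl on a saturated chain carbon bound to an amine nitrogen and a carbonyl carbon. Both compounds keep the shared core and the amine.

Going by the values given here, only one measured step exists, from compound 1 to compound 2, and it exchanges the whole amide substituent rather than the tert-butoxymethyl group alone. Among the compounds with values here, it was within the scatter, and no measured pair isolates the (tert-butoxy)methyl to tert-butyl change. There is therefore no evidence for a direction, and the expected step in this assay is none beyond the scatter, a 1.0-fold lower number from compound 2 to compound 3 (0.01 log units; within the scatter).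

For compound 3 the estimated value in this assay is 45000 nM, with a range from 15000 nM to 135000 nM.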

Compound 3, inhibition constant: 19100 nM
For compound 3 the middle estimate is 2.4-fold (0.37 log units) above the measured one; the measured number falls inside the stated range.
By their numbers in this assay, from the lowest: compound 3; then compounds 2 and 1 (each within the scatter of the next).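

In this assay, the group on the saturated chain carbon bound to an amine nitrogen and a carbonyl carbon now makes a difference beyond the scatter: tert-butyl in place of (tert-butoxy)methyl gives a 2.4-fold lower number from compound 2 to compound 3 (0.38 log units; beyond the scatter), a modest step. The same compound also separates from the pyrrolidin-2-yl amide, with 1-amino-2,2-dimethylpropyl in place of pyrrolidin-2-yl on a carbonyl carbon giving a 2.8-fold lower number from compound 1 to compound 3 (0.45 log units; beyond the scatter), again modest, whereas the earlier pair could not be told apart. No measurement shown here accounts for either step.

The change from (tert-butoxy)methyl to tert-butyl removes the ether oxygen and lowers the heavy-atom count together, so this single pair cannot show which of the two goes with the lower number. The compounds shown also leave open how the number would respond to an isopropyl group or a methoxymethyl group at this carbon, either of which would extend the comparison beyond these three amides.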